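This account rests on a few compounds, and the source may have more. Where it says the series, first, only, none or still open, it means among the compounds named here.

For the measured compounds named here, in a functional assay on MGC-803 cells (Homo sapiens) for inhibition, read by MTT assay, with a stated time of 72 h (on this read-out higher numbers stand for weaker inhibition and lower numbers for stronger inhibition), compound 3 `COc1ccc(Nc2nc(SCc3cn(CC(=O)NC(=O)Nc4ccccn4)nn3)nc(-c3ccc(C)cc3)c2C#N)cc1` gives 1700 nM, the lowest of the three numbers so far. Compound 1 `COc1cc(-c2nc(SCc3cn(CC(=O)NC(=O)Nc4ccccn4)nn3)nc(Nc3ccc(C)cc3)c2C#N)cc(OC)c1OC` gives 7030 nM, while compound 2 `Cc1ccc(-c2nc(SCc3cn(CC(=O)NC(=O)Nc4ccccn4)nn3)nc(Nc3ccc(C(C)C)cc3)c2C#N)cc1` gives 19300 nM. Compound 4 `Cc1ccc(Nc2nc(SCc3cn(CC(=O)NC(=O)Nc4ccccn4)nn3)nc(-c3ccc(C)cc3)c2C#N)cc1` differs from compound 3 by methyl in place of methoxy on an aromatic carbon. Going by the values given here, the only measured step at this position is an 11-fold lower number from compound 2 to compound 3 (1.06 log units; beyond the scatter), which shows that the group on this aromatic carbon has a large effect in this assay. Methyl is neither the isopropyl of compound 2 nor the methoxy of compound 3, so compound 4 is expected to land between those two neighbours, a moderate worsening estimated as a 2.1-fold higher number from compound 3 to compound 4 (0.31 log units; beyond the scatter). Compound 4 is therefore estimated at 3500 nM, with a range from 1500 nM to 9000 nM.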

Compound 4, half-maximal inhibitory concentration: 9890 nM
Compound 4: the middle estimate sits 2.8-fold (0.45 log units) below what was measured; the whole stated range lies below it.
By their numbers in this assay, from the lowest: compound 3; then compounds 1, 4 and 2 (each within the scatter of the next, the first and the last beyond it).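

In this assay methyl in place of methoxy gives a 5.8-fold higher number from compound 3 to compound 4 (0.76 log units; beyond the scatter) and so does not keep the low number of compound 3, whereas methyl in place of isopropyl gives a 2.0-fold lower number from compound 2 to compound 4 (0.29 log units; within the scatter) and leaves those two groups unseparated. Among these three groups, methoxy alone stands apart at this position, and on the other aromatic group 4-methylphenyl in place of 3,4,5-trimethoxyphenyl gives a 1.4-fold higher number from compound 1 to compound 4 (0.15 log units; within the scatter). Nothing available explains why methoxy differs from methyl. As far as these compounds go, whether ethoxy, a hydroxyl or an amine on this carbon would match methoxy remains open.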